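A few compounds are considered here, and "the series" means these few. Any claim that something is new, unique, unknown or untested is made for them only; others in the source may bear on it.

Results so far in a functional assay on KB cells (Homo sapiens) for cytotoxicity, read by MTT assay, with a stated time of 72 h (on this read-out higher numbers stand for weaker inhibition and lower numbers for stronger inhibition), are:
- compound 1 (`Cc1ccc(S(=O)(=O)c2nc3ccccc3nc2Nc2cccc(N)c2)cc1`) gives 10600 nM
- compound 2 (`COc1ccc(Nc2nc3ccccc3nc2S(=O)(=O)c2ccc(OC)cc2)cc1`) gives "not determined" (no result reported)

Compound 2 has no single number in this assay, so it offers no starting value and the step from it cannot be sized. Compound 3 (`COc1ccc(S(=O)(=O)c2nc3ccccc3nc2Nc2cccc(N)c2)cc1`) differs from compound 2 by one change (3-aminophenyl in place of 4-methoxyphenyl on a nitrogen on an aromatic ring), with 3-aminophenyl in place of 4-methoxyphenyl on a nitrogen on an aromatic ring. For the measured compounds named here, compound 1 at 10600 nM is the only number available, so a result near it is expected, with no shift in either direction beyond the usual scatter. For compound 3 the estimated value is 9000 nM (expected range 3000 nM to 30000 nM) in this assay for now.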

Compound 3, half-maximal inhibitory concentration: 4960 nM
Beside the measured number, compound 3's estimate is 1.8-fold (0.26 log units) above it; measured number inside the range.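

In this assay, with the rest of the core of compound 1 unchanged, methoxy in place of methyl on an aromatic carbon gives a 2.1-fold lower number from compound 1 to compound 3 (0.33 log units; beyond the scatter) as a modest step, the first size available for a change at this place. The step from compound 2 cannot be read, so 3-aminophenyl in place of 4-methoxyphenyl on the nitrogen stays unsized. No evidence on the cause of the step is available.

Going by these compounds, whether a chlorine or a carboxylic acid on that aromatic carbon would move the number further stays open. So does the effect of a hydroxyl in place of the amine on the 3-aminophenyl group.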